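This account rests on a few compounds, and the source may have more. Where it says the series, first, only, none or still open, it means among the compounds named here.

Measured compounds and their values:
compound 1, `C=C1C=CCO[C@@H]1n1cc(C)c(O)nc1=O`: 486000 nM
compound 2, `O=C(Nc1ccn([C@H]2OCC=CC2=O)c(=O)n1)c1ccccc1`: 28000 nM
compound 3, `C=C1[C@H](O)[C@H](O)CO[C@@H]1n1ccc(O)nc1=O`: > 800000 nM, which is a limit of the assay, not a number

All three come from a functional assay on L1210 cells (Mus musculus), with a stated time of 2 days; a lower number here means a stronger inhibitor, a higher number a weaker inhibitor. Compound 1 holds the highest of the two numbers; the nearest number, that of compound 2, lies well below it, a gap beyond the scatter. For compound 3 the result is the limit of > 800000 nM in this assay, at which 1 of the 3 values shown sits.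

Compound 4, `C=C1C=CCO[C@@H]1n1ccc(O)nc1=O`, differs from compound 1 only by hydrogen in place of methyl on an aromatic carbon. For the measured compounds named here, no measured pair of this kind is available, so the expectation rests on compound 1 alone. A small change, within the scatter and in no clear direction, is expected. Compound 4 is estimated at 500000 nM, in a range from 150000 nM to 1500000 nM, which means an expected step of a 1.0-fold higher number from compound 1 to compound 4 (0.01 log units; within the scatter).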

Compound 4, half-maximal inhibitory concentration: 549000 nM
Estimate against measurement, compound 4: 1.1-fold (0.04 log units) below; low and high end bracket the measured number.
By their numbers in this assay, from the lowest: compound 2; then compounds 1 and 4 (each within the scatter of the next). At a limit, above all of these: compound 3.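

Hydrogen in place of methyl on this aromatic carbon, ortho to a hydroxy group, gives a 1.1-fold higher number from compound 1 to compound 4 (0.05 log units; within the scatter), so in this assay compound 1 and compound 4 cannot be told apart. For the compounds shown here, this is the first pair here that differs in one place, and it shows that the methyl can go without a step beyond the scatter. Nothing measured here bears on why the step is this small.

Still open, as far as these compounds go, is whether fluorine, an amine or a longer chain on this carbon would move the number beyond the scatter. From the compounds shown here alone, whether the same swap behaves alike on the cores of compound 2 or compound 3 is also open.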